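From Compound 2 to Compound 3 on Huh-7 Cells

This account rests on a few compounds, and the source may have more. Where it says the series, first, only, none or still open, it means among the compounds named here.

Measured so far:
compound 1, `COc1cc2ccc(=O)oc2cc1OC(=O)c1c(C)noc1-c1ccc(Cl)cc1`: 12400 nM
compound 2, `COc1cc2ccc(=O)oc2cc1OC(=O)c1c(-c2ccc(Cl)cc2)n[nH]c1C`: 16200 nM

In a functional assay on Huh-7 cells (Homo sapiens) for inhibition, read by MTT assay, with a stated time of 48 h (on this read-out higher numbers stand for weaker inhibition and lower numbers for stronger inhibition), compound 2 gives 16200 nM, and compound 1 gives 12400 nM. Of the two numbers, that of compound 2 is the higher, but the two lie within the scatter of each other, so neither can be called the stronger inhibitor on this evidence.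

Compound 3, `COc1cc2ccc(=O)oc2cc1OC(=O)c1c(-c2ccccc2F)n[nH]c1C`, has not yet been measured in this assay. It differs from compound 2 in one place: 2-fluorophenyl in place of 4-chlorophenyl on an aromatic carbon. For the measured compounds named here, the two measured compounds do not share a step of this kind, so no measured step guides the expectation directly.

The step of a 1.2-fold higher number from compound 2 to compound 3 (0.09 log units; within the scatter) is expected to be small, at most a slight move toward weaker inhibition, and not clearly beyond the scatter. Compound 3 is therefore estimated at 20000 nM in this assay, with a range from 8000 nM to 50000 nM.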

Compound 3, half-maximal inhibitory concentration: > 25000 nM
Compound 3 ended at the assay's limit; the forecaster's own chance of this, stated with the estimate: 10%; at least 1.2-fold (0.09 log units) between middle value and limit.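

In this assay compound 3 gives > 25000 nM, which is a limit of the assay and not a number. For the compounds shown here, putting 2-fluorophenyl in place of 4-chlorophenyl on this aromatic carbon of the five-membered ring gives an at least 1.5-fold higher number from compound 2 to compound 3 (0.18 log units; that floor lies within the scatter), the first one-place step that can be read, and it shows only a floor, one that does not clear the scatter. The true size of the step stays unknown because the reading stops at the assay's limit: the limit of > 25000 nM in this assay, at which 1 of the 3 values shown sits.

Compound 2 and compound 3 differ in both the halogen and its place on the phenyl ring, so the step cannot be assigned to either one. On these data alone, how a 4-fluorophenyl or a 2-chlorophenyl on this carbon would read remains open, as does the effect of a plain phenyl.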